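A Ring Swap Tested in Mice

The compounds below may be only part of what the source reports. "The series", "measured", "known", "first", "only" and "open" are said of these compounds alone.

In a functional assay on the whole organism for antagonist activity, with Mus musculus as the target (a lower number here means that less compound is needed, a higher number that more compound is needed for the effect), compound 1 `COC(=O)N(C)C(C)C#CCN1CCCC1` reaches only a limit of > 100 mg/kg. Compound 2 `COC(=O)N(C)C(C)C#CCn1ccnc1` likewise stops at a limit of > 100 mg/kg. Compound 3 `CC(C#CCN1CCCC1)N1CCN(C)C1=O` gives a number in this assay, namely 37 mg/kg. Compound 4 `CC(C#CCn1ccnc1)N1CCN(C)C1=O` has not yet been measured in this assay.

The change from compound 1 to compound 2 is 1H-imidazol-1-yl in place of pyrrolidin-1-yl on a saturated chain carbon bound to a triple-bonded carbon, and its step is a step that the two limits leave unreadable from compound 1 to compound 2. The same change is made from compound 3 to compound 4: 1H-imidazol-1-yl in place of pyrrolidin-1-yl on a saturated chain carbon bound to a triple-bonded carbon. The difference between the two cores is not broken down here. Most shown values rest at the limit of > 100 mg/kg in this assay, at which 2 of the 3 values shown sit.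

The measured step of this change is unreadable, so the expectation rests on compound 3 alone, with its value 37 mg/kg. Compound 4 is expected to come out near 80 mg/kg. That means an expected step of a 2.2-fold higher number from compound 3 to compound 4 (0.33 log units; beyond the scatter).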

Compound 4, dose for half-maximal effect: > 100 mg/kg
Compound 4 was reported as a limit; the forecaster's own chance of this, stated with the estimate: 55%; at least 1.2-fold (0.09 log units) between middle value and limit.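

In this assay, putting 1H-imidazol-1-yl in place of pyrrolidin-1-yl on the core with the measured number gives an at least 2.7-fold higher number from compound 3 to compound 4 (0.43 log units; beyond the scatter). As far as these compounds go, the same change on the core of compound 1 cannot be read, so nothing shows whether the step carries over between the cores or how its size compares, because both values on that core are limits: the limit of > 100 mg/kg in this assay, at which 3 of the 4 values shown sit. The result for compound 4 is also a limit, and the full size of its step stays unknown.

Going by these compounds alone, compound 3 remains the only one with a number, at 37 mg/kg. From the compounds shown here alone, whether a piperidin-1-yl or a diethylamino group on that chain carbon would give a number on either core stays open.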